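This account rests on a few compounds, and the source may have more. Where it says the series, first, only, none or still open, it means among the compounds named here.

Within the data shown here, compound 2 `Cc1cccc(S(=O)(=O)N2CCC(N3CCC(C)CC3)CC2)c1` gives 25 nM in a functional assay on DLD-1 cells (Homo sapiens) for antiproliferative activity, read by CellTiter-Glo, with a stated time of 72 h (on this read-out lower numbers stand for stronger inhibition and higher numbers for weaker inhibition), the only number among the values shown. Compound 1 `CC1CCN(C2CCN(S(=O)(=O)c3cccc(C(F)(F)F)c3)CC2)CC1` returns only a limit in this assay, > 5000 nM (the limit of > 5000 nM in this assay, at which 1 of the 2 values shown sits). Among the measured compounds shown here, the single measured step, an at least 200-fold lower number from compound 1 to compound 2 (2.30 log units; beyond the scatter), is large. Compound 3 `COc1cccc(S(=O)(=O)N2CCC(N3CCC(C)CC3)CC2)c1` differs from compound 2 by methoxy in place of methyl on an aromatic carbon. That change sits at the same place but exchanges a different pair of groups, so the measured step bears on it only loosely, and a move within the scatter or a modest one is expected. Compound 3 is accordingly estimated at 50 nM, between 15 nM and 250 nM. The expected step is a 2.0-fold higher number from compound 2 to compound 3 (0.30 log units; within the scatter).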

Compound 3, half-maximal inhibitory concentration: > 5000 nM
Compound 3: only a limit was reported; the forecaster's own chance of this, stated with the estimate: 5%; middle value at least 100-fold (2.00 log units) from the limit.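

Methoxy in place of methyl gives an at least 200-fold higher number from compound 2 to compound 3 (2.30 log units; beyond the scatter) in this assay, so a second group at this place on the aromatic ring, not only trifluoromethyl, loses the activity seen with methyl. The step between compound 1 and compound 3 cannot be read, since both carry only a limit. Among the three compounds, only the one with methyl returns a number, and the other two stand at the limit: the limit of > 5000 nM in this assay, at which 2 of the 3 values shown sit.

As far as these compounds go, it remains open whether a chlorine, an ethyl or a hydroxyl at this place would keep activity in this assay.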